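A few compounds are considered here, and "the series" means these few. Any claim that something is new, unique, unknown or untested is made for them only; others in the source may bear on it.

Measured compounds in this series:
- compound 1 `COc1cccc(/C=C/C(=O)c2sc(Nc3ccccc3)nc2C)c1` — > 25000 nM
- compound 2 `COc1cccc(/C=C/C(=O)c2sc(Nc3ccccc3C)nc2C)c1` — > 25000 nM
- compound 3 `COc1ccc(/C=C/C(=O)c2sc(Nc3ccc(Cl)c(Cl)c3)nc2C)cc1` — > 25000 nM

All three were tested in a functional assay on NCI-H460 cells (Homo sapiens) for cytotoxicity, read by MTT assay; a higher number here means a weaker inhibitor, a lower number a stronger inhibitor. For compound 1 the value is a limit, not a number. For compound 2 the value is likewise a limit. For compound 3 the value is again a limit, so compound 3 stands where the other two stand, with no number to separate it from them (the limit of > 25000 nM in this assay, at which 3 of the 3 values shown sit). Within the data shown here, the one measured step, a step that the two limits leave unreadable from compound 1 to compound 2, is unreadable; both of its ends are limits.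

Compound 4 `COc1cccc(/C=C/C(=O)c2sc(Nc3ccc(Cl)c(Cl)c3)nc2C)c1` remains to be measured. It differs from compound 3 by 3-methoxyphenyl in place of 4-methoxyphenyl on a double-bonded chain carbon bound to a double-bonded chain carbon. Among the measured compounds shown here, no measured step covers this change. Compound 1 already carries the 3-methoxyphenyl group on the same core with a different aromatic amine and gives only a limit > 25000 nM. Apart from that one difference, compound 4 matches compound 3. Compound 3 also gives only a limit > 25000 nM. Nothing measured here points to a readable gain. Compound 4 is therefore expected to give 30000 nM, with a range from 10000 nM to 100000 nM, most probably reported once more as a limit. The expected step is a step that the limit leaves unreadable from compound 3 to compound 4, no change beyond the scatter.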

Compound 4, half-maximal inhibitory concentration: 20100 nM
Beside the measured number, compound 4's estimate is 1.5-fold (0.17 log units) above it; the measured number falls inside the stated range.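

In this assay, among these compounds, compound 4 gives the only value that is a number rather than a limit, and moving the methoxy group, 3-methoxyphenyl in place of 4-methoxyphenyl on a double-bonded chain carbon bound to a double-bonded chain carbon, gives an at least 1.2-fold lower number from compound 3 to compound 4 (0.09 log units; that floor lies within the scatter). On the nitrogen on an aromatic ring, 3,4-dichlorophenyl in place of 2-methylphenyl gives an at least 1.2-fold lower number from compound 2 to compound 4 (0.09 log units; that floor lies within the scatter), and 3,4-dichlorophenyl in place of phenyl gives an at least 1.2-fold lower number from compound 1 to compound 4 (0.09 log units; that floor lies within the scatter). Each of these steps is only a floor, so its true size stays unknown, and among these four compounds only compound 4 pairs 3-methoxyphenyl with 3,4-dichlorophenyl and reaches a number: the limit of > 25000 nM in this assay, at which 3 of the 4 values shown sit.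

Open, as far as these compounds go, is whether a hydroxyl or a dimethylamino group in place of the methoxy group on the same chain carbon would keep, lose or extend this readable value. Also open, from the compounds shown here alone, is whether 3,4-dichlorophenyl is needed in full on the nitrogen, or whether 3-chlorophenyl or a carboxylic acid on that phenyl ring would serve with 3-methoxyphenyl held constant.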